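Removing the Prop-1-en-1-yl Group from Compound 1

The source may hold more compounds than are shown below. What is called first, only, known or untested is meant among the compounds shown, and "the series" means these compounds.

Compound 1 `C/C=C/C1=C(CO)[C@H](O)[C@H]2O[C@H]2C1=O` was tested in a functional assay on SKW 6.4 cells (Homo sapiens); on this read-out higher numbers stand for an effect only at larger amounts of compound and lower numbers for an effect already at smaller amounts. In this assay compound 1 gives only a limit, > 80 uM. Compound 2 `C/C=C(\C)C1=C(CO)[C@H](O)[C@H]2O[C@H]2C1=O` likewise gives only a limit, > 80 uM. Compound 3 `C/C=C/C1=C(CO)[C@@H](O)[C@@H]2O[C@@H]2C1=O` also gives only a limit, > 80 uM. The step that the two limits leave unreadable from compound 1 to compound 2 and the step that the two limits leave unreadable from compound 1 to compound 3 therefore cannot be read, because of the limit of > 80 uM in this assay, at which 3 of the 3 values shown sit; compound 3 is set apart from compound 1 only because of the fact that compounds 1 and 3 differ only in the configuration as drawn. Compound 4 `O=C1C=C(CO)[C@H](O)[C@H]2O[C@@H]12` differs from compound 1 by hydrogen in place of prop-1-en-1-yl on a double-bonded ring carbon. Within the data shown here, no measured step bears on this change, and every known value sits at the same limit, so the expected step that the limit leaves unreadable from compound 1 to compound 4 cannot be sized from the data beyond the expectation that compound 4 will also remain at the limit. Compound 4 is therefore estimated at 120 uM, within 30 uM to 400 uM.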

Compound 4, concentration for half-maximal effect: > 80 uM
Compound 4 gave a limit, no number (the forecaster's own chance of this, stated with the estimate: 85%); the middle value is on the limit's open side.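

Compound 4 also gives only a limit in this assay, so the steps from compound 1 and from compound 2 to compound 4 cannot be read: the limit of > 80 uM in this assay, at which 4 of the 4 values shown sit. From the compounds shown here alone, whether the group on the double-bonded ring carbon or the configuration matters in this assay stays open.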